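A few compounds are considered here, and "the series" means these few. Any claim that something is new, unique, unknown or untested is made for them only; others in the source may bear on it.

Compound 1 `CC(C)C[C@H](N)CN(C(=O)[C@@H]1C[C@H]1c1ccccc1)c1ccc(-c2ccccc2)cc1` gives 880 nM in a functional assay for agonist activity at G protein-coupled receptor 88 (Homo sapiens), read by HTRF and cAMP accumulation; on this read-out lower numbers stand for an effect already at smaller amounts and higher numbers for an effect only at larger amounts of compound. Compound 2 `Cc1cccc(-c2ccc(N(C[C@@H](N)CC(C)C)C(=O)[C@@H]3C[C@H]3c3ccccc3)cc2)c1` gives 1200 nM. Compound 3 `COc1ccccc1-c1ccc(N(C[C@@H](N)CC(C)C)C(=O)[C@@H]2C[C@H]2c2ccccc2)cc1` gives 3200 nM.

All three share one core and differ only in what is attached to the outer aromatic ring. Compound 3 stands at the highest number of the three: the step of a 3.6-fold higher number from compound 1 to compound 3 (0.56 log units; beyond the scatter) and the step of a 2.7-fold higher number from compound 2 to compound 3 (0.43 log units; beyond the scatter) both lie beyond the scatter, whereas the step of a 1.4-fold higher number from compound 1 to compound 2 (0.13 log units; within the scatter) does not, so compound 1 and compound 2 cannot be told apart.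

Compound 4 `CC(C)C[C@H](N)CN(C(=O)[C@@H]1C[C@H]1c1ccccc1)c1ccc(-c2cccc(C#N)c2)cc1` has not yet been measured. It differs from compound 3 in one place: 3-cyanophenyl in place of 2-methoxyphenyl on an aromatic carbon. Within the data shown here, two measured steps bear on this. Removing the methoxy from compound 3 gave the number of compound 1, and exchanging 2-methoxyphenyl for 3-methylphenyl gave the number of compound 2, both lower. The 3-cyanophenyl of compound 4 follows the substitution pattern of the 3-methylphenyl of compound 2 rather than that of compound 3, so a step down, of about the size seen between compound 2 and compound 3, is expected: a 2.7-fold lower number from compound 3 to compound 4 (0.43 log units; beyond the scatter). On that basis compound 4 is estimated at 1200 nM in this assay, with a range from 400 nM to 4000 nM.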

Compound 4, half-maximal effective concentration: 4500 nM
The estimate for compound 4 lay 3.8-fold (0.57 log units) below the measured number; measured number above the stated range.
By their numbers in this assay, from the lowest: compounds 1 and 2 (each within the scatter of the next); then compounds 3 and 4 (each within the scatter of the next).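

Swapping one group for another on the same aromatic carbon is enough to shift the number: with cyano in place of methyl, a 3.8-fold higher number from compound 2 to compound 4 (0.57 log units; beyond the scatter) in this assay, so the 3-substituted pattern shared by the 3-methylphenyl and the 3-cyanophenyl does not by itself set the result. Cyano in place of hydrogen gives a 5.1-fold higher number from compound 1 to compound 4 (0.71 log units; beyond the scatter), the largest step in this small set, whereas 3-cyanophenyl in place of 2-methoxyphenyl gives a 1.4-fold higher number from compound 3 to compound 4 (0.15 log units; within the scatter), so these two differently substituted rings cannot be told apart here, and of the three groups on the outer ring only methyl, in compound 2, stays within the scatter of the unsubstituted compound 1. Nothing measured here explains why the nitrile and the methoxy behave alike or why the methyl differs from them.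

Methoxy appears only as 2-methoxyphenyl and cyano only as 3-cyanophenyl, so the effect of the group and the effect of its place on the ring remain unseparated. As far as these compounds go, it also remains open how the number would respond to a hydroxyl, an amine or a carboxylic acid on this ring.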